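Swapping the cap of compound 1 for a chlorinated ring

The compounds below may be only part of what the source reports. "The series", "measured", "known", "first", "only" and "open" are said of these compounds alone.

The two compounds measured here share a core and differ in what hangs from it. Compound 1, `O=C(NO)c1ccc(-c2ccc(CNCCOc3ccccc3)cn2)s1`, carries an extended side chain and gives 110 nM in a functional assay on MCF7 cells (Homo sapiens) for inhibition; on this read-out lower numbers stand for stronger inhibition and higher numbers for weaker inhibition. Compound 2, `O=C(NO)c1ccc(-c2ccccc2)s1`, keeps only a bare phenyl on the core and gives 31000 nM in this assay. Compound 1 thus holds the lower of the two numbers, and the gap between the two values lies well beyond the scatter.

Compound 3, `O=C(NO)c1ccc(-c2ccc(CNCc3ccccc3Cl)cn2)s1`, has not been measured. It keeps the full chain of compound 1 and changes only its terminal group: 2-chlorophenyl in place of phenoxymethyl on a saturated chain carbon bound to an amine nitrogen. The amine and the linker to the core remain untouched, so the change sits far from the part that compound 2 lacks. Among the compounds with values here, no single-change step is available to calibrate such a swap. The step from compound 1 to compound 3 is expected to be small, close to none beyond the scatter, perhaps slightly weaker: a 1.4-fold higher number from compound 1 to compound 3 (0.13 log units; within the scatter). Compound 3 is accordingly estimated at 150 nM, within a range of 50 nM to 500 nM.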

Compound 3, half-maximal inhibitory concentration: 110 nM
Estimate against measurement, compound 3: 1.4-fold (0.13 log units) above; the measured number falls inside the stated range.
By their numbers in this assay, from the lowest: compounds 1 and 3 (each within the scatter of the next); then compound 2.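

Read in this assay, putting 2-chlorophenyl in place of phenoxymethyl on a saturated chain carbon bound to an amine nitrogen gives no change at the digits printed from compound 1 to compound 3 (within the scatter), and this is the only single-place step in the set. It shows that the terminal group of the side chain can be exchanged without a change that stands out from the scatter, even though the group that leaves carries a hydrogen-bond acceptor and the group that enters carries none and brings in chlorine. The data offer no measurement that would explain why these two terminal groups read alike in this cell assay.

As far as these compounds go, what remains open is how much of this tolerance belongs to the ring itself and how much to the chlorine, a question that a plain phenyl on the same carbon would address. Also open, from the compounds shown here alone, is whether the position would accept a very different terminal group, such as a carboxylic acid or a morpholine ring, or a longer chain carrying the same 2-chlorophenyl.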